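Swapping the sulfonyl aryl group on a shared indole core

The compounds below may be only part of what the source reports. "The series", "measured", "known", "first", "only" and "open" are said of these compounds alone.

Measured compounds and their results in a functional assay on HEK293 cells for antagonist activity at 5-hydroxytryptamine receptor 6 (Homo sapiens), read by cAMP accumulation, with stated times of 10 min and 1 h; a lower number here means a stronger inhibitor, a higher number a weaker inhibitor:
- Compound 1, `Cc1c(/C=N/N2CCN(C)CC2)c2ccccc2n1S(=O)(=O)c1ccc(F)cc1`: 4740 nM
- Compound 2, `CN1CCN(/N=C/c2c(-c3ccccc3)n(S(=O)(=O)c3ccccc3)c3ccccc23)CC1`: 1800 nM
- Compound 3, `COc1cc(C)c(Cl)cc1S(=O)(=O)n1c(-c2ccccc2)c(/C=N/N2CCN(C)CC2)c2ccccc21`: 7400 nM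

Among the compounds with values here, compound 3 carries the highest number of the three, but its gap to compound 1 lies within the usual scatter, so the two cannot be ranked; only its gap to compound 2 is large enough to count, and that pair is also the only measured step that bears on the change in hand: a 4.1-fold higher number from compound 2 to compound 3 (0.61 log units; beyond the scatter).

Compound 4, `CN1CCN(/N=C/c2c(-c3ccccc3)n(S(=O)(=O)c3ccc(F)cc3)c3ccccc23)CC1`, differs from compound 3 in one place: 4-fluorophenyl in place of 5-chloro-2-methoxy-4-methylphenyl on a sulfonyl sulfur. This largely undoes the change that separated compound 2 from compound 3, bringing the sulfonyl group back to a plain ring bearing a single fluorine. Compound 1, which carries the same 4-fluorophenyl group on its sulfonyl sulfur but a methyl rather than a phenyl elsewhere on the core, gives 4740 nM, a number close to that of compound 3.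

The expectation in this assay is therefore a drop roughly the size of the measured step in reverse, landing near compound 2: compound 4 is estimated at 2500 nM, with a range from 1000 nM to 6000 nM, meaning a 3.0-fold lower number from compound 3 to compound 4 (0.47 log units; beyond the scatter).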

Compound 4, half-maximal inhibitory concentration: 2900 nM
The estimate for compound 4 lay 1.2-fold (0.06 log units) below the measured number, within the range that was stated.
By their numbers in this assay, from the lowest: compounds 2, 4, 1 and 3 (each within the scatter of the next, the first and the last beyond it).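

Moving a 2.6-fold lower number from compound 3 to compound 4 (0.41 log units; beyond the scatter) in this assay shows that the higher number of compound 3 can be reversed from the other direction: with the phenyl on the core kept, 4-fluorophenyl on the sulfonyl sulfur reads clearly lower than 5-chloro-2-methoxy-4-methylphenyl. The fluorine itself makes no readable difference, since the change a 1.6-fold higher number from compound 2 to compound 4 (0.21 log units; within the scatter) cannot be told apart from repeat-measurement noise, so among these compounds only the 5-chloro-2-methoxy-4-methylphenyl group separates from the two simpler rings on that core. The new compound also bears on the other varied place, where the change a 1.6-fold lower number from compound 1 to compound 4 (0.21 log units; within the scatter) again cannot be read as a real difference, so phenyl and methyl on that aromatic carbon give results that cannot be ranked when 4-fluorophenyl sits on the sulfur.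

Still open, from the compounds shown here alone, is which of the chloro, methoxy and methyl groups on the ring of compound 3 accounts for its step, and how an amine on the sulfonyl ring would read. Nothing available here explains any of these numbers.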